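This account rests on a few compounds, and the source may have more. Where it says the series, first, only, none or still open, it means among the compounds named here.

Measured in an ADME assay on HEK293 cells (Homo sapiens) for cytotoxicity, read by MTT assay, with a stated time of 72 h; on this read-out higher numbers stand for weaker inhibition and lower numbers for stronger inhibition:
- Compound 1 `COc1ccc(C2=C(c3cc(OC)c(OC)c(OC)c3)C(=O)CC2O[SiH2]C(C)(C)C)cc1`: > 100 ug/mL (a limit of the assay)
- Compound 2 `COc1ccc(C2=C(c3cc(OC)c(OC)c(OC)c3)C(=O)C(O)C2)cc1`: 6.3 ug/mL

Compound 1 gives no number, and stands at the limit of > 100 ug/mL in this assay, at which 1 of the 2 values shown sits. Compound 2 gives a measured number, 6.3 ug/mL.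

Compound 3 `COc1ccc(OC)c(C2=C(c3cc(OC)c(OC)c(OC)c3)C(=O)CC2O[SiH2]C(C)(C)C)c1` keeps the core of compound 1 and carries 2,5-dimethoxyphenyl in place of 4-methoxyphenyl on a double-bonded ring carbon. Among the compounds with values here, no measured pair in this assay shows what such a change does, so no step beyond the usual scatter is expected, and a weak reading should persist. This expectation rests on compound 1 alone, whose reading is the limit > 100 ug/mL. The estimated change is a number no higher from compound 1 to compound 3 (the limit leaves the size open). For compound 3 the expected value is 100 ug/mL, within an estimated range of 35 ug/mL to 250 ug/mL.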

Compound 3, half-maximal inhibitory concentration: 9.5 ug/mL
Compound 3: the middle estimate sits 11-fold (1.02 log units) above what was measured, outside the stated range (below it).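

In this assay, the group on this double-bonded ring carbon proves able to shift the reading on its own: 2,5-dimethoxyphenyl in place of 4-methoxyphenyl gives an at least 10-fold lower number from compound 1 to compound 3 (1.02 log units; beyond the scatter). With the rest of the core of compound 1 kept, compound 3 gives a measured 9.5 ug/mL, so this core can also give a measured number. Compound 1 reads > 100 ug/mL, which is a limit of the assay, so the full size of the step stays unknown: the limit of > 100 ug/mL in this assay, at which 1 of the 3 values shown sits.

The compounds shown do not tell whether the added methoxy group or the new placement of the methoxy groups carries the step. As far as these compounds go, how an amine or a carboxylic acid on this phenyl ring would read also remains open.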